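Ring swap on the thiocarbonyl carbon: working notes

This account rests on a few compounds, and the source may have more. Where it says the series, first, only, none or still open, it means among the compounds named here.

Measured so far in an ADME assay on HEK293 cells (Homo sapiens) for inhibition, read by MTT assay, with stated times of 18 h and 4 h; a lower number here means a stronger inhibitor, a higher number a weaker inhibitor
- compound 1 `CCCCCCCCCCOP(=O)(O)OCCSC(=S)N1CCCCCC1` gives 70000 nM
- compound 2 `CCCCCCCCCCOP(=O)(O)OCCSC(=S)N1CCCC1` gives > 100000 nM (a limit)

Not yet measured
- compound 3 `CCCCCCCCCCOP(=O)(O)OCCSC(=S)N1CCCCC1`

Compound 2 stands at > 100000 nM and that is a limit, not a number. The change to compound 3 is piperidin-1-yl in place of pyrrolidin-1-yl on a thiocarbonyl carbon. Among the measured compounds shown here, only one measured step bears on this, namely an at least 1.4-fold higher number from compound 1 to compound 2 (0.15 log units; that floor lies within the scatter) and it gives a floor, not a size. The expected step is an at least 1.2-fold lower number from compound 2 to compound 3 (0.09 log units; that floor lies within the scatter) in this assay and nothing beyond the scatter is expected. For compound 3 the estimate is 80000 nM within 45000 nM to 130000 nM as the expected range.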

Compound 3, half-maximal inhibitory concentration: 70700 nM
Compound 3: the middle estimate sits 1.1-fold (0.05 log units) above what was measured, within the range that was stated.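

In this assay piperidin-1-yl in place of azepan-1-yl gives a 1.0-fold higher number from compound 1 to compound 3 (0.00 log units; within the scatter), so on this thiocarbonyl carbon these two rings cannot be told apart. The step from the five-membered ring, an at least 1.4-fold lower number from compound 2 to compound 3 (0.15 log units; that floor lies within the scatter), gives only a floor and shows no difference beyond the scatter. Compound 2 remains a limit and not a number: the limit of > 100000 nM in this assay, at which 1 of the 3 values shown sits.

From the compounds shown here alone, how far compound 2 truly lies from the other two stays open. Also open, going by these compounds, is what morpholin-4-yl or an open-chain diethylamino group would give on this carbon.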